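This account rests on a few compounds, and the source may have more. Where it says the series, first, only, none or still open, it means among the compounds named here.

Working notes on the series. The shared core carries a 2,4-difluorophenyl group, a ((2-(4-methylpiperazin-1-yl)ethyl)amino)methyl group and a variable aryl group. Compound 1 is `CN1CCN(CCNCc2cn(-c3ccc(F)cc3F)nc2-c2ccc(OC(F)(F)F)cc2)CC1`; in an ADME assay on Huh-7 cells (Homo sapiens) for cytotoxicity (on this read-out lower numbers stand for higher toxicity in this test and higher numbers for lower toxicity in this test), compound 1 gives 18000 nM. Compound 2, `CN1CCN(CCNCc2cn(-c3ccc(F)cc3F)nc2-c2ccc(C(F)(F)F)cc2)CC1`, gives 20000 nM in this assay. Compound 3 is `CN1CCN(CCNCc2cn(-c3ccc(F)cc3F)nc2-c2ccc(N(C)C)cc2)CC1`. In this assay compound 3 returns only a limit, > 20000 nM, and so sits at the limit of > 20000 nM in this assay, at which 1 of the 3 values shown sits. The measured steps are a 1.1-fold higher number from compound 1 to compound 2 (0.05 log units; within the scatter) and an at least 1.1-fold higher number from compound 1 to compound 3 (0.04 log units; that floor lies within the scatter), while a number no lower from compound 2 to compound 3 (the limit leaves the size open). Within these three compounds the exchange of the group on the aryl ring has not moved the read-out beyond the scatter, and compound 3 stands at the limit of the numbers shown.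

Compound 4 is `CN1CCN(CCNCc2cn(-c3ccc(F)cc3F)nc2-c2cccc(N(C)C)c2)CC1`. It differs from compound 3 by 3-(dimethylamino)phenyl in place of 4-(dimethylamino)phenyl on an aromatic carbon. Among the compounds with values here, no measured step concerns moving a dimethylamino group from one ring carbon to another; the steps that exist concern only exchange of the group itself, two of them within the scatter and the third unreadable in size. The expectation for compound 4 in this assay is therefore a step of a number no higher from compound 3 to compound 4 (the limit leaves the size open), with no change beyond the scatter. Compound 4 is estimated at 20000 nM, between 10000 nM and 40000 nM, with a fair chance that this assay again returns only a limit.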

Compound 4, half-maximal cytotoxic concentration: > 20000 nM
Compound 4: a limit, no number; the forecaster's own chance of this, stated with the estimate: 50%; the middle value sits exactly at the limit.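

In this assay compound 4 also returns only a limit, so 3-(dimethylamino)phenyl in place of 4-(dimethylamino)phenyl gives no measurable size for this change at this position. The size of the step against the trifluoromethyl compound cannot be read either: there is a number no lower from compound 2 to compound 4 (the limit leaves the size open). Within the data shown here, the one step that can be read is an at least 1.1-fold higher number from compound 1 to compound 4 (0.04 log units; that floor lies within the scatter), and it gives a floor, not a size. New here is a step that the two limits leave unreadable from compound 3 to compound 4, with the dimethylamino group now at two places on the phenyl ring, neither of which yields a number. The limit is now shared: the limit of > 20000 nM in this assay, at which 2 of the 4 values shown sit.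

From the compounds shown here alone, the true values of compound 3 and compound 4 stay open, and with them whether the two placements of the dimethylamino group differ at all in this read-out. Also open, going by these compounds, is whether a carboxylic acid or a primary amine on that phenyl ring in place of dimethylamino, or a longer chain between the core and the 4-methylpiperazine, would bring the read-out to a number.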